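From a Hydroxypentyl Chain to Dimethylamino

A few compounds are considered here, and "the series" means these few. Any claim that something is new, unique, unknown or untested is made for them only; others in the source may bear on it.

In an ADME assay on PBMC cells (Homo sapiens) for cytotoxicity, with a stated time of 5 days (a higher number here means a weaker inhibitor, a lower number a stronger inhibitor), compound 1 (`C=CCNc1nc(N)nc2c1ncn2[C@H]1C[C@H](N=[N+]=[N-])[C@@H](CO)O1`) gives > 100000 nM, a limit of the assay and not a number. Compound 2 (`[N-]=[N+]=N[C@H]1C[C@H](n2cnc3c(NCCCCCO)nc(N)nc32)O[C@@H]1CO`) gives > 100000 nM, also a limit. Among the measured compounds shown here, the one measured step, a step that the two limits leave unreadable from compound 1 to compound 2, therefore has no readable size. Compound 3 (`CN(C)c1nc(N)nc2c1ncn2[C@H]1C[C@H](N=[N+]=[N-])[C@@H](CO)O1`) carries dimethylamino in place of (5-hydroxypentyl)amino on an aromatic carbon. For the measured compounds named here, the only guide is the limit of > 100000 nM in this assay, at which 2 of the 2 values shown sit, which suggests no clear shift in this assay. The expected change is a number no higher from compound 2 to compound 3 (the limit leaves the size open), with no shift beyond the scatter foreseen. The estimate for compound 3 is 100000 nM, with an expected range of 40000 nM to 200000 nM.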

Compound 3, half-maximal inhibitory concentration: > 100000 nM
Compound 3 ended at the assay's limit (the forecaster's own chance of this, stated with the estimate: 75%); the middle value lies on the limit itself.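

Among the compounds shown here, no step among compound 1, compound 2 and compound 3 can be read, because all three values are limits and not numbers: the limit of > 100000 nM in this assay, at which 3 of the 3 values shown sit. The compounds shown leave open how allylamino, (5-hydroxypentyl)amino and dimethylamino compare in this assay.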